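Swapping the aryl group on the fused ring amide

The compounds below may be only part of what the source reports. "The series", "measured", "known", "first", "only" and "open" are said of these compounds alone.

Compound 1 `Fc1cc(Nc2cc(Nc3ccc(Cl)cc3)ncn2)ccc1Oc1ccncc1-c1cccnc1`: 1610 nM
Compound 2 `Cn1c(=O)c(C(=O)Nc2ccc(Oc3ccncc3-c3cccnc3)c(F)c2)nn(-c2c(Cl)cccc2Cl)c1=O`: 720 nM
Compound 3 `COc1ccc(-n2nc(C(=O)Nc3ccc(Oc4ccncc4-c4cccnc4)c(F)c3)c3ccccc3c2=O)cc1`: 6800 nM

All three share a core carrying the same diaryl ether and pyridine portion, and were tested in a functional assay on A549 cells (Homo sapiens) for cytotoxicity, read by MTT assay, with a stated time of 72 h; on this read-out higher numbers stand for weaker inhibition and lower numbers for stronger inhibition. Compound 3 gives the highest number of the three: compound 1 and compound 2 both give lower numbers, and each of those gaps lies beyond the usual scatter, so compound 3 is the weakest inhibitor among these measured compounds.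

Compound 4 `O=C(Nc1ccc(Oc2ccncc2-c2cccnc2)c(F)c1)c1nn(-c2cccc(F)c2)c(=O)c2ccccc12` differs from compound 3 in a single place: 3-fluorophenyl in place of 4-methoxyphenyl on an aromatic nitrogen. The core, the amide linkage and the rest of the molecule stay the same.

Going by the values given here, no measured pair in this set shows what such a swap does, so there is no direct precedent to lean on. Because compound 3 gives 6800 nM, the expectation is that compound 4 stays in the same region, with a step of a 1.4-fold lower number from compound 3 to compound 4 (0.13 log units; within the scatter) that is expected to be small, likely within the scatter, with a slight lean toward a lower number. Compound 4 is estimated at 5000 nM, within a range from 1500 nM to 16000 nM.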

Compound 4, half-maximal inhibitory concentration: 1750 nM
Beside the measured number, compound 4's estimate is 2.9-fold (0.46 log units) above it, and the stated range covers the measured number.
By their numbers in this assay, from the lowest: compound 2; then compounds 1 and 4 (each within the scatter of the next); then compound 3.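

The aryl group on the aromatic nitrogen is not a silent position: in this assay, replacing 4-methoxyphenyl with 3-fluorophenyl leads to a 3.9-fold lower number from compound 3 to compound 4 (0.59 log units; beyond the scatter), a modest step. Going by these compounds alone, until this pair, no two measured compounds differed in only one place, so none of the earlier numbers could be tied to a single group. No measured evidence here accounts for the size or direction of this step, so it stands as an observation only.

This swap alters both the substituent and where it sits on the phenyl ring, so the pair cannot separate those two changes. From the compounds shown here alone, how plain phenyl, or a phenyl ring carrying an amine or a carboxylic acid, would behave on this nitrogen remains open.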